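Replacing the benzoyl group of compound 2

This account rests on a few compounds, and the source may have more. Where it says the series, first, only, none or still open, it means among the compounds named here.

In a functional assay on SW480 cells (Homo sapiens) for antiproliferative activity, read by MTT assay, with a stated time of 48 h (on this read-out higher numbers stand for weaker inhibition and lower numbers for stronger inhibition), compound 1 `OCCC(COCc1ccccc1)n1cnc2c(Cl)ncnc21` gives > 50000 nM as a limit of the assay and not a number. Compound 2 `O=C(OCC(CCO)n1cnc2c(Cl)ncnc21)c1ccccc1` gives > 50000 nM and this too is only a limit. Compound 2 therefore has no exact place on the scale, and what the data show is the limit of > 50000 nM in this assay, at which 2 of the 2 values shown sit, with no number behind either compound.

The next structure is compound 3 `CC(C)(C)[Si](C)(C)OCC(CCO)n1cnc2c(Cl)ncnc21` and the change that leads to it is a group of 7 heavy atoms (6 carbon, 1 silicon; no ring) in place of a group of 8 heavy atoms (7 carbon, 1 oxygen; one six-membered aromatic ring of carbon only), on an oxygen on a saturated carbon at the same site. A benzoyl group with its aromatic ring leaves, and a group with no ring enters.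

Within the data shown here, the only measured step is a step that the two limits leave unreadable from compound 1 to compound 2 and it gives no size to carry forward. No size or direction of change in this assay can be drawn from it. Compound 1 and compound 2 both sit at the limit, so another limit is the likeliest expected result, although a measurable value cannot be ruled out.

The expected change is a number no higher from compound 2 to compound 3 (the limit leaves the size open) and this remains only an estimate. For compound 3 the estimated value is 50000 nM with an expected range of 15000 nM to 100000 nM on this assay.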

Compound 3, half-maximal inhibitory concentration: 31700 nM
For compound 3 the middle estimate is 1.6-fold (0.20 log units) above the measured one; the measured number falls inside the stated range.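

Among these compounds, with the group of 7 heavy atoms (6 carbon, 1 silicon; no ring) on an oxygen on a saturated carbon, this assay yields the only actual number among the three structures: compound 3 gives 31700 nM. This change reads as an at least 1.5-fold lower number from compound 2 to compound 3 (0.19 log units; that floor lies within the scatter), and the matching comparison reads as an at least 1.5-fold lower number from compound 1 to compound 3 (0.19 log units; that floor lies within the scatter), so an aromatic ring at this site is not required for a measurable value, although neither floor shows a change beyond the usual scatter. The step between compound 1 and compound 2 cannot be read, as both carry only a limit of the assay: the limit of > 50000 nM in this assay, at which 2 of the 3 values shown sit.

The compounds shown do not separate the part played by the silicon atom from that played by the loss of the aromatic ring, and the true distance of compound 3 from compound 1 and compound 2 stays unknown. They also leave open whether a methyl group, a longer saturated chain or a chain ending in an amine on the same oxygen would give a lower number or return to the limit.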